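A few compounds are considered here, and "the series" means these few. Any claim that something is new, unique, unknown or untested is made for them only; others in the source may bear on it.

Measured so far in a physicochemical assay for lipophilicity, using the shake flask method, in phosphate buffer, measured as octanol-water partition, with a stated time of 5 h; on this read-out lower numbers stand for lower lipophilicity and higher numbers for higher lipophilicity: compound 1 `O=C(CN1CCN(c2cc3c(cc2F)c(=O)c(C(=O)O)cn3C2CC2)CC1)Nc1ccc(C(=O)/C=C/c2ccccc2Cl)cc1` gives 1.29; compound 2 `O=C(CN1CCN(c2cc3c(cc2F)c(=O)c(C(=O)O)cn3C2CC2)CC1)Nc1ccc(C(=O)/C=C/c2ccc(Cl)cc2)cc1` gives 0.471.

Compound 2 holds the lowest of the two numbers in this assay, with compound 1 the nearest at a step of a number 0.82 log units lower from compound 1 to compound 2 (beyond the scatter). The step now followed leads from compound 2 to compound 3 `COc1ccc(/C=C/C(=O)c2ccc(NC(=O)CN3CCN(c4cc5c(cc4F)c(=O)c(C(=O)O)cn5C4CC4)CC3)cc2)cc1OC`, not yet measured in this assay. The change is 3,4-dimethoxyphenyl in place of 4-chlorophenyl on a double-bonded chain carbon bound to a double-bonded chain carbon, a swap that leaves the rest of the shared core untouched.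

Going by the values given here, no measured step covers this exact exchange, since the one step seen, from compound 1 to compound 2, only moved a chlorine atom to another spot on the same ring and still shifted the number by a number 0.82 log units lower from compound 1 to compound 2 (beyond the scatter). That shows the place is sensitive, but gives no direction for a new ring group with two acceptors in place of a chlorine. With this in mind, compound 3 is expected to sit near compound 2, with a wide range allowed, estimated at 0.15 (from -0.65 to 0.95), which would mean a step of a number 0.32 log units lower from compound 2 to compound 3 (beyond the scatter).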

Compound 3, partition coefficient: 1.46
Beside the measured number, compound 3's estimate is 1.31 log units below it; the whole stated range lies below it.
By their numbers in this assay, from the lowest: compound 2; then compounds 1 and 3 (each within the scatter of the next).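

In this assay, the place on a double-bonded chain carbon bound to a double-bonded chain carbon now shows a change of group as well as a shift of chlorine: 3,4-dimethoxyphenyl in place of 4-chlorophenyl gives a number 0.99 log units higher from compound 2 to compound 3 (beyond the scatter) and so reverses the direction of the earlier step, a number 0.82 log units lower from compound 1 to compound 2 (beyond the scatter) in this same assay. The same group in place of 2-chlorophenyl gives a number 0.17 log units higher from compound 1 to compound 3 (within the scatter) and so leaves compound 1 and compound 3 at one level despite their different ring groups, which makes compound 2, with its 4-chlorophenyl, the only one of the three that stands apart, with the lowest number. Nothing available bears on the reason for these steps.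

The compounds shown leave open whether both methoxy groups are needed for this level or a ring with only one of them would read the same. They also leave open how a plain phenyl, or a ring carrying an amine or a hydroxyl group, would read at this place.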